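The source may hold more compounds than are shown below. What is called first, only, known or untested is meant among the compounds shown, and "the series" means these compounds.

Compound 3, `COc1ccc(/C=C/C(=O)c2cccc(-n3cc(-c4ccc(F)cc4)nn3)c2)cc1O`, gives 2500 nM in a functional assay on RAW264.7 cells (Mus musculus) for inhibition, with a stated time of 4 days (a higher number here means a weaker inhibitor, a lower number a stronger inhibitor), the lowest of the three numbers measured. Compound 2, `COc1ccc(/C=C/C(=O)c2cccc(-n3cc(C(C)(C)O)nn3)c2)cc1O`, gives 17100 nM, and the step of a 6.8-fold lower number from compound 2 to compound 3 (0.84 log units; beyond the scatter) was modest. Compound 1, `COc1cc(/C=C/C(=O)c2cccc(-n3cc(-c4ccc(C)cc4)nn3)c2)ccc1O`, which carries a 4-methylphenyl but differs elsewhere, gives 15400 nM. Compound 4, `COc1ccc(/C=C/C(=O)c2cccc(-n3cc(-c4ccc(C)cc4)nn3)c2)cc1O`, differs from compound 3 by methyl in place of fluoro on an aromatic carbon. For the measured compounds named here, no measured step bears directly on this exchange; the only measured step concerns a different group. Since compound 1 with the same 4-methylphenyl shows 15400 nM, a somewhat higher number than compound 3 is expected, though the two compounds differ elsewhere. Compound 4 is therefore estimated at 4500 nM, within 1500 nM to 13000 nM, an expected step of a 1.8-fold higher number from compound 3 to compound 4 (0.26 log units; within the scatter).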

Compound 4, half-maximal inhibitory concentration: 1700 nM
Compound 4: middle estimate off by 2.6-fold (0.42 log units), on the high side; low and high end bracket the measured number.
By their numbers in this assay, from the lowest: compounds 4 and 3 (each within the scatter of the next); then compounds 1 and 2 (each within the scatter of the next).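

In this assay the exchange of fluoro for methyl at this position separates nothing, as the step stays within the scatter (a 1.5-fold lower number from compound 3 to compound 4 (0.17 log units; within the scatter)). The 4-methylphenyl, like the 4-fluorophenyl, stands clear of the 1-hydroxy-1-methylethyl (a 10-fold lower number from compound 2 to compound 4 (1.00 log units; beyond the scatter)), while the swap between 4-hydroxy-3-methoxyphenyl and 3-hydroxy-4-methoxyphenyl, now seen on its own, also counts (a 9.1-fold lower number from compound 1 to compound 4 (0.96 log units; beyond the scatter)). Nothing given here explains these steps. Open, as far as these compounds go, is whether a chlorine, a methoxy or an amine in this place would stay with methyl and fluoro, and whether the hydroxy and methoxy swap would carry over to the 4-fluorophenyl series.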